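Swapping Thiophene for Furan at a Saturated Ring Carbon

A few compounds are considered here, and "the series" means these few. Any claim that something is new, unique, unknown or untested is made for them only; others in the source may bear on it.

Measured so far:
compound 1, `CCOC(=O)C1=C(C)N/C(=N\C#N)NC1c1cccs1`: 3%
compound 2, `CCOC(=O)C1=C(C)N/C(=N\C#N)NC1c1ccsc1`: 23%

Both compounds were tested in an assay on HeLa cells for displacement of a labelled ligand from adenosine receptor A3 (Homo sapiens), with a stated time of 180 min, tested at 1 uM; a higher number here means more inhibition at the concentration tested (going by the name of the read-out), a lower number less inhibition. Within the data shown here, compound 2 holds the higher of the two numbers, and the one step seen so far, a number 20 percentage points higher from compound 1 to compound 2 (beyond the scatter), is beyond the scatter.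

Compound 3, `CCOC(=O)C1=C(C)N/C(=N\C#N)NC1c1ccco1`, has not yet been measured. The change from compound 2 is furan-2-yl in place of thiophen-3-yl on a saturated ring carbon. Among the measured compounds shown here, the only measured step, a number 20 percentage points higher from compound 1 to compound 2 (beyond the scatter), concerns a different part of the same ring, the attachment point, and no measured pair compares sulfur against oxygen, so that step bears only loosely on this one. Compound 3 is therefore expected to show a small downward step, a number 11 percentage points lower from compound 2 to compound 3 (beyond the scatter), and the estimate is uncertain. Compound 3 is estimated at 12%, with a range from 0% to 30%.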

Compound 3, a percentage reported as inhibition, at one concentration (the size of the read-out at that concentration, not a potency): 20%
Beside the measured number, compound 3's estimate is 8 percentage points below it, within the range that was stated.
By their numbers in this assay, from the lowest: compound 1; then compounds 3 and 2 (each within the scatter of the next).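

In this assay, among these compounds, the step from thiophen-2-yl to furan-2-yl, a number 17 percentage points higher from compound 1 to compound 3 (beyond the scatter), is the first comparison of sulfur with oxygen in which the ring stays attached through the same position. The other new step, a number 3 percentage points lower from compound 2 to compound 3 (within the scatter), changes both the hetero atom and the attachment point, yet it leaves compound 2 and compound 3 within the scatter of each other. Among these three groups on the saturated ring carbon, only thiophen-2-yl stands apart, with the lowest number, so a five-membered aromatic ring at this position does not by itself set the result.

No supporting data are available to explain these differences. As far as these compounds go, it remains open how furan-3-yl, a phenyl ring or a group carrying an amine would read out on this same carbon.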